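Substituent series on the shared core: diethylamino step

The source may report more compounds than this note shows. Statements on the series, on what has been measured and on what is new or still open speak of the compounds shown alone.

Working notes on the series. Compound 1 `CCCc1ccc(N2C(=O)NC3(CSC4=C3C(=O)c3ncccc3C4=O)C2=O)cc1`, compound 2 `COc1ccc(N2C(=O)NC3(CSC4=C3C(=O)c3ncccc3C4=O)C2=O)cc1` and compound 3 `O=C1C2=C(C(=O)c3ncccc31)C1(CS2)NC(=O)N(c2ccc([N+](=O)[O-])cc2)C1=O` share one core and differ only in the group on the aromatic carbon para to the large group. In a functional assay on HT-29 cells (Homo sapiens) for antiproliferative activity, read by MTT assay, with a stated time of 96 h (a lower number here means a stronger inhibitor, a higher number a weaker inhibitor), compound 1 gives 1 nM, compound 2 gives 2 nM and compound 3 gives 250 nM. Compound 1 has the lowest number of the three: the step of a 2.0-fold higher number from compound 1 to compound 2 (0.30 log units; within the scatter) stays within the scatter, whereas a 250-fold higher number from compound 1 to compound 3 (2.40 log units; beyond the scatter) and a 130-fold higher number from compound 2 to compound 3 (2.10 log units; beyond the scatter) are both large, beyond the scatter.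

Compound 4 `CCN(CC)c1ccc(N2C(=O)NC3(CSC4=C3C(=O)c3ncccc3C4=O)C2=O)cc1` is not yet measured. It differs from compound 1 by diethylamino in place of propyl on an aromatic carbon. Within the data shown here, two measured steps bear on this change. Replacing propyl with methoxy, a 2.0-fold higher number from compound 1 to compound 2 (0.30 log units; within the scatter), leaves the number essentially unchanged; replacing it with nitro, a 250-fold higher number from compound 1 to compound 3 (2.40 log units; beyond the scatter), raises it sharply. Only the nitro compound shows a large step in this set, so a diethylamino group is expected to behave more like the methoxy case, with a step that is small or within the scatter, if anything toward a slightly higher number. Compound 4 is therefore expected to give 2 nM in this assay, with a range of 0.5 nM to 15 nM. The expected step of a 2.0-fold higher number from compound 1 to compound 4 (0.30 log units; within the scatter) is estimated to be modest.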

Compound 4, half-maximal inhibitory concentration: 50 nM
For compound 4 the middle estimate is 25-fold (1.40 log units) below the measured one, outside the stated range (above it).
By their numbers in this assay, from the lowest: compounds 1 and 2 (each within the scatter of the next); then compound 4; then compound 3.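

In this assay, the large steps at this position are no longer confined to nitro: a 50-fold higher number from compound 1 to compound 4 (1.70 log units; beyond the scatter) and a 25-fold higher number from compound 2 to compound 4 (1.40 log units; beyond the scatter) show that diethylamino is also poorly accommodated on an aromatic carbon para to a large group, although methoxy and propyl remain within the scatter of each other. The change from nitro, a 5.0-fold lower number from compound 3 to compound 4 (0.70 log units; beyond the scatter), is only modest, so diethylamino falls between the propyl and methoxy pair and nitro rather than matching either end of the series. Among these four compounds, the two higher numbers belong to compound 3 and compound 4, the two whose group is attached to the aromatic carbon through nitrogen, and no compound here goes against that pattern, but the data shown give no measured reason for the loss of activity.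

The compounds shown leave open whether the rise follows the attached nitrogen or the two ethyl chains of diethylamino. A plain amine, a dimethylamino group or a butyl chain at the same position would help separate those two readings.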